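Oxygen to sulfur on the butyl side chain

The source may report more compounds than this note shows. Statements on the series, on what has been measured and on what is new or still open speak of the compounds shown alone.

Working notes on a small series built on one shared core, which carries a chloro or an alkoxy group on an aromatic carbon. Compound 1 `Clc1nccnc1C1CN2CCC1CC2` gives in a functional assay on A9L-m1 cells with A9 (Mus musculus) as the target (on this read-out higher numbers stand for larger maximal responses and lower numbers for smaller maximal responses), 13%. Compound 2 `CCOc1nccnc1C1CN2CCC1CC2` gives in this assay 1%, and compound 3 `CCCCOc1nccnc1C1CN2CCC1CC2` gives in this assay 15%. The measured steps are a number 12 percentage points lower from compound 1 to compound 2 (beyond the scatter), a number 2 percentage points higher from compound 1 to compound 3 (within the scatter) and a number 14 percentage points higher from compound 2 to compound 3 (beyond the scatter).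

Compound 3 therefore holds the highest of the three numbers, but its distance to compound 1 is within the scatter, and only its distance to compound 2 is beyond it.

Compound 4 `CCCCSc1nccnc1C1CN2CCC1CC2` differs from compound 3 in one place: butylsulfanyl in place of butoxy on an aromatic carbon. Going by the values given here, none of the measured steps bears on this change directly: the steps of a number 2 percentage points higher from compound 1 to compound 3 (within the scatter) and a number 14 percentage points higher from compound 2 to compound 3 (beyond the scatter) concern the length of the alkoxy chain and the exchange of chloro, while the atom through which the chain attaches to the ring stays oxygen in every measured compound. There is thus no basis in these data for a step beyond the scatter, and compound 4 is expected to sit near compound 3, with no change at the digits printed from compound 3 to compound 4 (within the scatter) as the estimated step. For compound 4 the estimate in this assay is 15%, with a range from 3% to 28%.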

Compound 4, largest response reached (reported as maximum), in percent of the reference or control that the assay uses: 5%
Estimate against measurement, compound 4: 10 percentage points above; the range from low to high includes it.
By their numbers in this assay, from the lowest: compounds 2, 4, 1 and 3 (each within the scatter of the next, the first and the last beyond it).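

Changing the atom that attaches the butyl chain to the aromatic carbon next to the ring nitrogen gives a number 10 percentage points lower from compound 3 to compound 4 (within the scatter) in this assay, so this first exchange away from oxygen at this position cannot be told from repeat scatter. Butylsulfanyl also stays close to both other groups at this position, with a number 4 percentage points higher from compound 2 to compound 4 (within the scatter) and a number 8 percentage points lower from compound 1 to compound 4 (within the scatter), whereas the step from ethoxy to butoxy is a number 14 percentage points higher from compound 2 to compound 3 (beyond the scatter); compound 4 therefore cannot be assigned to either side of that gap. No data shown here offer an explanation for the value of compound 4.

On these data alone, whether a true difference between butoxy and butylsulfanyl lies hidden within the scatter remains open, and ethylsulfanyl, the direct sulfur partner of the ethoxy group in compound 2, would show whether the chain-length step seen with oxygen also appears with sulfur. A butylamino group or a longer chain such as hexyloxy at the same position would test whether any other attaching atom or chain length moves the read-out beyond the scatter from compound 3.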